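A few compounds are considered here, and "the series" means these few. Any claim that something is new, unique, unknown or untested is made for them only; others in the source may bear on it.

Measured so far in a functional assay on A549 cells (Homo sapiens) for cytotoxicity, read by MTT assay, with a stated time of 72 h; a lower number here means a stronger inhibitor, a higher number a weaker inhibitor:
- compound 1 `COc1ccc(Nc2nc3ccccc3nc2S(=O)(=O)c2ccccc2)cc1`: 11900 nM
- compound 2 `COc1cc(Nc2nc3ccccc3nc2S(=O)(=O)c2ccccc2)cc(OC)c1OC`: 9660 nM
- compound 3 `O=S(=O)(c1ccccc1)c1nc2ccccc2nc1Nc1ccc(F)cc1`: a limit only, > 50000 nM

Compound 2 gives the lowest of the two numbers in this assay; the nearest is compound 1, and the gap between compound 1 and compound 2 lies within the scatter. Compound 3 sits at the assay limit (the limit of > 50000 nM in this assay, at which 1 of the 3 values shown sits). Among the measured compounds shown here, the only measured step, an at least 4.2-fold higher number from compound 1 to compound 3 (0.62 log units; beyond the scatter), concerns fluoro in place of methoxy and does not touch the phenylsulfonyl.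

Compound 4 `COc1cc(Nc2nc3ccccc3nc2S(=O)(=O)c2ccc(C)cc2)cc(OC)c1OC` differs from compound 2 by methyl in place of hydrogen on an aromatic carbon. For the measured compounds named here, no measured step bears on this change, so for compound 4 the expectation in this assay is a step of no more than the scatter, a 1.1-fold lower number from compound 2 to compound 4 (0.03 log units; within the scatter). The estimate for compound 4 is 9000 nM, expected between 3000 nM and 30000 nM.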

Compound 4, half-maximal inhibitory concentration: 5610 nM
For compound 4 the middle estimate is 1.6-fold (0.21 log units) above the measured one, and the stated range covers the measured number.
By their numbers in this assay, from the lowest: compounds 4, 2 and 1 (each within the scatter of the next, the first and the last beyond it). At a limit, above all of these: compound 3.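

Among the compounds shown here, the first change to the phenylsulfonyl gives, in this assay, a 1.7-fold lower number from compound 2 to compound 4 (0.24 log units; within the scatter). Phenylsulfonyl to (4-methylphenyl)sulfonyl therefore leaves the trimethoxy-bearing compound 4 level with compound 2, and this one pair gives a first reading that a methyl para to a large group is accommodated on this ring. No observation at hand bears on this step.

From the compounds shown here alone, whether an amine, a carboxylic acid or a longer chain at this place would behave as methyl does remains open. So does whether the same change would read alike on compound 1.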